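A few compounds are considered here, and "the series" means these few. Any claim that something is new, unique, unknown or untested is made for them only; others in the source may bear on it.

Measured compounds:
- compound 1, `O=C1C(=O)N(Cc2ccc(-c3cccnc3)cn2)c2ccc(OC(F)(F)F)cc21`: "not determined" (no result reported)
- compound 2, `O=C1C(=O)N(Cc2ccc(-c3ccccc3)cc2)c2ccc(OC(F)(F)F)cc21`: < 60%

Both compounds were examined in a functional assay on CHO cells for positive allosteric modulation of muscarinic acetylcholine receptor M5 (Homo sapiens), read by FLIPR and calcium flux, with a stated time of 1 h; a lower number here means a smaller maximal response, a higher number a larger maximal response. Compound 1 stands with no number in this assay: its result was simply not reported, so there is no value to build on. Compound 2 is the only one that gives a result, and that result is a limit rather than a number, as the limit of < 60% in this assay, at which 1 of the 2 values shown sits, records.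

Compound 3, `O=C1C(=O)N(Cc2ccc(-c3ccccc3)cn2)c2ccc(OC(F)(F)F)cc21`, differs from compound 1 in one place: phenyl in place of pyridin-3-yl on an aromatic carbon. Going by the values given here, because compound 1 carries no value, no step size from compound 1 to compound 3 can be stated in this assay, neither upward nor downward, and no step between measured compounds is available to borrow from. Among the compounds with values here, the one measurement at hand, the limit for compound 2, points toward a small maximal response rather than a large one.

On that basis compound 3 is expected to give roughly 45% in this assay, with a likely range from 20% to 75%, and a fair chance that only a limit is reported.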

Compound 3, largest response reached (Emax), in percent of the reference or control that the assay uses: 47%
Compound 3: the middle estimate sits 2 percentage points below what was measured; the measured number falls inside the stated range.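

Going by these compounds alone, compound 1 has no reported result in this assay, so no step from compound 1 to compound 3 can be read. Nothing given here bears on the result for compound 3. The compounds shown leave open whether exchanging pyridin-3-yl for phenyl changes the largest response at all.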